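Enone series on a benzoxaborole core: aryl ketone variations

The source may hold more compounds than are shown below. What is called first, only, known or untested is meant among the compounds shown, and "the series" means these compounds.

The three measured compounds share one core and differ only in the ring on the carbonyl carbon. Compound 1 `O=C(/C=C/c1ccc2c(c1)B(O)OC2)c1ccccc1` carries phenyl and in a functional assay on MDA-MB-231 cells (Homo sapiens) for cytotoxicity, read by MTT assay, with a stated time of 48 h (a higher number here means a weaker inhibitor, a lower number a stronger inhibitor), gives 2300 nM. Compound 2 `O=C(/C=C/c1ccc2c(c1)B(O)OC2)c1cccs1` carries thiophen-2-yl and in this assay gives 4600 nM, so that a 2.0-fold higher number from compound 1 to compound 2 (0.30 log units; within the scatter). Compound 3 `Cn1cccc1C(=O)/C=C/c1ccc2c(c1)B(O)OC2` carries 1-methyl-1H-pyrrol-2-yl. In this assay, among the measured compounds shown here, compound 3 gives > 100000 nM, which is a limit of the assay and not a number; it is the one value sitting at the limit of > 100000 nM in this assay, at which 1 of the 3 values shown sits. Compound 3 therefore stands apart from the other two, with an at least 43-fold higher number from compound 1 to compound 3 (1.63 log units; beyond the scatter) and an at least 21-fold higher number from compound 2 to compound 3 (1.33 log units; beyond the scatter).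

Compound 4 `O=C(/C=C/c1ccc2c(c1)B(O)OC2)c1ccc(F)cc1` is not yet measured. The change from compound 3 is 4-fluorophenyl in place of 1-methyl-1H-pyrrol-2-yl on a carbonyl carbon. For the measured compounds named here, the steps that bear on it are the two large ones into compound 3, which are reversed here in sense: a six-membered carbon ring returns in place of the five-membered ring with one nitrogen. Because the step of an at least 43-fold higher number from compound 1 to compound 3 (1.63 log units; beyond the scatter) was large, a large step back downwards is expected, an at least 40-fold lower number from compound 3 to compound 4 (1.60 log units; beyond the scatter). Going by the values given here, no measured pair shows the effect of the fluorine itself. Compound 4 is therefore estimated at 2500 nM, with a range from 700 nM to 9000 nM.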

Compound 4, half-maximal inhibitory concentration: 1600 nM
Beside the measured number, compound 4's estimate is 1.6-fold (0.19 log units) above it, and the stated range covers the measured number.
By their numbers in this assay, from the lowest: compounds 4, 1 and 2 (each within the scatter of the next, the first and the last beyond it). At a limit, above all of these: compound 3.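

In this assay, fluoro in place of hydrogen on an aromatic carbon gives a 1.4-fold lower number from compound 1 to compound 4 (0.16 log units; within the scatter), so this change leaves compound 1 and compound 4 level and the position on the ring tolerates the fluorine without a readable shift. The 4-fluorophenyl group does separate from thiophen-2-yl on the same carbonyl carbon, with a 2.9-fold lower number from compound 2 to compound 4 (0.46 log units; beyond the scatter), a modest gap that the phenyl and thiophen-2-yl pair did not show beyond the scatter. The largest step, an at least 62-fold lower number from compound 3 to compound 4 (1.79 log units; beyond the scatter), confirms that a six-membered aromatic ring of carbon only sits far from 1-methyl-1H-pyrrol-2-yl here, but it gives only a bound, its upper end being a limit and not a number: the limit of > 100000 nM in this assay, at which 1 of the 4 values shown sits.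

Still open, as far as these compounds go, is whether a methoxy group, a dimethylamino group or a carboxylic acid in place of the fluoro on that aromatic carbon would stay level with compound 1. Also open, from the compounds shown here alone, is whether the gap at compound 3 follows the ring itself or its methyl group, a question that an unmethylated 1H-pyrrol-2-yl or a furan-2-yl on the carbonyl carbon would address.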